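The source may hold more compounds than are shown below. What is called first, only, known or untested is meant among the compounds shown, and "the series" means these compounds.

Measured compounds:
compound 1 `CCCSc1nnc(COc2ccccc2C2=NOC(c3ccc(Cl)cc3Cl)C2)n1NC(=O)c1ccccc1`: 14.8 ug/mL
compound 2 `CCOC(=O)CC(=O)CSc1nnc(COc2ccccc2C2=NOC(c3ccc(Cl)cc3Cl)C2)n1NC(C)=O`: "not determined" (no result reported)

Among the measured compounds shown here, compound 1 carries the only number. In an ADME assay (MDM cells, Homo sapiens) for cytotoxicity, read by resazurin assay, with a stated time of 3 days (a lower number here means a stronger inhibitor, a higher number a weaker inhibitor), compound 1 gives 14.8 ug/mL. For the measured compounds named here, compound 2 was run in this assay but returned no value, so no step between two measured compounds exists and compound 1 cannot be set against a neighbour; it stands alone.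

Compound 3 `CSc1nnc(COc2ccccc2C2=NOC(c3ccc(Cl)cc3Cl)C2)n1NC(=O)c1ccccc1` differs from compound 1 in one place: hydrogen in place of ethyl on a saturated chain carbon bound to a sulfur; read one bond further out, propylsulfanyl becomes methylsulfanyl. Going by the values given here, with no measured pair to lean on, the expectation for this shortening rests on the structural change alone and is put at a step of a 1.2-fold higher number from compound 1 to compound 3 (0.09 log units; within the scatter), expected to stay within the usual scatter and, if anything, to lean towards a weaker inhibitor. Compound 3 is therefore estimated at 18 ug/mL in this assay, with a range from 7 ug/mL to 45 ug/mL.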

Compound 3, half-maximal inhibitory concentration: 2.2 ug/mL
Estimate against measurement, compound 3: 8.2-fold (0.91 log units) above; measured number outside the range, below it.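

In this assay, among the compounds shown here, the change from propylsulfanyl to methylsulfanyl gives a 6.7-fold lower number from compound 1 to compound 3 (0.83 log units; beyond the scatter) and is the first readable step. The saturated chain on the sulfur is therefore a place where this read-out responds, and removing ethyl from it is enough to carry the result beyond the scatter. Nothing at hand explains the size or direction of this step.

With only the propyl and methyl chains compared, this is one step in one direction and not a trend with chain length. Going by these compounds, an ethyl chain, a longer chain such as butyl, and a chain ending in an amine or a carboxylic acid remain open, as does whether the same step holds with other groups on the shared core.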